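Chloro in place of phenoxy: compound 3 to compound 4

The source may hold more compounds than are shown below. What is called first, only, known or untested is meant among the compounds shown, and "the series" means these compounds.

In an ADME assay on HEK293 cells (Homo sapiens) for cytotoxicity, read by luminescence, with a stated time of 72 h (a higher number here means that more compound is needed for the effect, a lower number that less compound is needed), compound 3 (`CCOC(=O)c1c(-c2cccc(Oc3ccccc3)c2)[nH]c2cc(OC)c(Cl)cc2c1=O`) gives > 22000 nM as a limit, not a number. Compound 1 (`CCOC(=O)c1c(-c2cccc(-c3ccccc3)c2)[nH]c2cc(OC)c(Cl)cc2c1=O`) gives > 22000 nM as a limit too. Compound 2 (`CCOC(=O)c1c(-c2cccc(OC)c2)[nH]c2cc(OC)c(Cl)cc2c1=O`) likewise gives > 22000 nM as a limit. Going by the values given here, the series so far therefore stands at the limit of > 22000 nM in this assay, at which 3 of the 3 values shown sit, and offers no exact reading.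

Compound 4 (`CCOC(=O)c1c(-c2cccc(Cl)c2)[nH]c2cc(OC)c(Cl)cc2c1=O`) carries chloro in place of phenoxy on an aromatic carbon, meta to a large group (chloro in place of phenoxy on an aromatic carbon).

The measured steps that bear on this change the group at that same place. They are a step that the two limits leave unreadable from compound 1 to compound 3 together with a step that the two limits leave unreadable from compound 2 to compound 3 and a step that the two limits leave unreadable from compound 1 to compound 2 as the third. None of them has a readable size, so they set no scale for the change, but phenyl, methoxy and phenoxy all leave the reading at the same limit. On that basis, no step beyond the scatter is expected in this assay and no direction is expected either. The estimated step is a number no higher from compound 3 to compound 4 (the limit leaves the size open) on this reasoning. A report as a limit is the most likely outcome. For compound 4 the estimated value is 22000 nM with an expected range from 11000 nM to 40000 nM in all.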

Compound 4, half-maximal effective concentration: > 22000 nM
Compound 4: only a limit was reported; the forecaster's own chance of this, stated with the estimate: 85%; the middle value lies on the limit itself.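

In this assay compound 4 gives > 22000 nM, a limit and not a number. Its steps from compound 1, compound 2 and compound 3 therefore cannot be read. The compounds shown leave open whether phenyl, methoxy, phenoxy and chloro differ at all at this place, with no exact reading in the series: the limit of > 22000 nM in this assay, at which 4 of the 4 values shown sit.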